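The source may hold more compounds than are shown below. What is called first, only, known or untested is meant among the compounds shown, and "the series" means these compounds.

Measured so far in a functional assay on HCT-116 cells (Homo sapiens) for antiproliferative activity, read by MTT assay, with a stated time of 72 h; a higher number here means a weaker inhibitor, a lower number a stronger inhibitor:
- compound 1 `NC1=NC2(CCOCC2)N(OCCCOc2ccccc2)C(N)=N1` gives 6010 nM
- compound 2 `Cc1cc(C)cc(OCCCON2C(N)=NC(N)=NC23CCOCC3)c1` gives 190 nM
- compound 3 `NC1=NC2(CCOCC2)N(OCCCOc2cc(Cl)c(Cl)cc2Cl)C(N)=N1` gives 2750 nM

Compound 1 has the highest number of the three, beyond the scatter against both others. Compound 4 `NC1=NC2(CCOCC2)N(OCCCOc2ccc(Br)cc2)C(N)=N1` differs from compound 1 by bromo in place of hydrogen on an aromatic carbon. Both prior steps change the same phenyl ring on the oxygen on a saturated carbon: a 32-fold lower number from compound 1 to compound 2 (1.50 log units; beyond the scatter) and a 2.2-fold lower number from compound 1 to compound 3 (0.34 log units; beyond the scatter), while a 14-fold higher number from compound 2 to compound 3 (1.16 log units; beyond the scatter) shows how far the two substituted rings lie apart. A single bromo resembles the halogenated case more than the dimethyl case, so a modest downward step in this assay is expected, as a 2.4-fold lower number from compound 1 to compound 4 (0.38 log units; beyond the scatter). Compound 4 is accordingly estimated at 2500 nM, with a range from 800 nM to 8000 nM.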

Compound 4, half-maximal inhibitory concentration: 320 nM
Compound 4: the middle estimate sits 7.8-fold (0.89 log units) above what was measured; the whole stated range lies above it.
By their numbers in this assay, from the lowest: compounds 2 and 4 (each within the scatter of the next); then compound 3; then compound 1.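

In this assay, a bromo on the aromatic carbon para to a large group gives a 19-fold lower number from compound 1 to compound 4 (1.27 log units; beyond the scatter), so this one position alone can carry a large step. Halogen as such does not set the level: the 4-bromophenyl ring gives an 8.6-fold lower number from compound 3 to compound 4 (0.93 log units; beyond the scatter), while a 1.7-fold higher number from compound 2 to compound 4 (0.23 log units; within the scatter) leaves the 4-bromophenyl and 3,5-dimethylphenyl rings unseparated. Nothing at hand accounts for these steps. Open, going by these compounds, is whether a 4-chlorophenyl, 4-methoxyphenyl or 4-aminophenyl ring would behave like the 4-bromophenyl ring. Also open, on these data alone, is whether the 4-bromophenyl result holds with a longer chain to the core.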